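A Larger Carbon Ring on the Amide Nitrogen

The source may report more compounds than this note shows. Statements on the series, on what has been measured and on what is new or still open speak of the compounds shown alone.

Three compounds share one core and differ only in the group on an amide-type nitrogen. In an in vitro ADME assay on microsomes from liver (Homo sapiens) for pharmacokinetics, read by LC-MS, with a stated time of 10 min, tested at 1 uM (on this read-out higher numbers stand for fast clearance and lower numbers for slow clearance), compound 1 `CN1C[C@H](C(=O)Nc2ccc(F)cc2)[C@@H](c2ccc(/C=C/C(=O)Nc3ccccc3N)cc2)C1` gives 5 mL/min/kg and compound 2 `CN1C[C@H](C(=O)Nc2ccccc2F)[C@@H](c2ccc(/C=C/C(=O)Nc3ccccc3N)cc2)C1` gives 10 mL/min/kg. Compound 3 `CN1C[C@H](C(=O)NC2CC2)[C@@H](c2ccc(/C=C/C(=O)Nc3ccccc3N)cc2)C1`, which carries cyclopropyl at that place, gives 10 mL/min/kg. This puts it level with compound 2 and within the usual scatter of compound 1.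

The next compound changes that same group. Compound 4 `CN1C[C@H](C(=O)NC2CCCC2)[C@@H](c2ccc(/C=C/C(=O)Nc3ccccc3N)cc2)C1` differs from compound 3 in one place: cyclopentyl in place of cyclopropyl on an amide-type nitrogen. In words, it has cyclopentyl in place of cyclopropyl on an amide-type nitrogen.

Among the compounds with values here, three measured steps bear on this change, since each exchanges the group on that nitrogen. They are a 2.0-fold higher number from compound 1 to compound 2 (0.30 log units; within the scatter), a 2.0-fold higher number from compound 1 to compound 3 (0.30 log units; within the scatter) and no change at the digits printed from compound 2 to compound 3 (within the scatter). None of them leaves the scatter, even though the groups exchanged differ considerably. However, none of them goes from one saturated carbon ring to a larger one, so this evidence is indirect.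

No step beyond the scatter is therefore expected in this assay, and the estimated step is a 1.2-fold higher number from compound 3 to compound 4 (0.08 log units; within the scatter). Compound 4 is expected at 12 mL/min/kg, with an estimated range of 6 mL/min/kg to 24 mL/min/kg.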

Compound 4, clearance: 9 mL/min/kg
For compound 4 the middle estimate is 1.3-fold (0.12 log units) above the measured one; the measured number falls inside the stated range.
By their numbers in this assay, from the lowest: compounds 1, 4, 2 and 3 (each within the scatter of the next).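

Enlarging the saturated carbon ring on the amide-type nitrogen from cyclopropyl to cyclopentyl adds carbon atoms, yet in this assay the step stays within the scatter (a 1.1-fold lower number from compound 3 to compound 4 (0.05 log units; within the scatter)). Cyclopentyl also stays within the scatter of both fluorophenyl groups (a 1.1-fold lower number from compound 2 to compound 4 (0.05 log units; within the scatter); a 1.8-fold higher number from compound 1 to compound 4 (0.26 log units; within the scatter)), so across these four compounds, no exchange at this position leaves the scatter, and none of the four goes against that pattern. Within the data shown here, this is the first direct comparison of two saturated carbon rings here, but no measurement at hand accounts for the lack of a clear difference.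

As far as these compounds go, it remains open whether a larger carbon ring such as cyclohexyl, or an open longer chain such as hexyl, would stay within the scatter on this nitrogen. It is equally open whether a ring carrying an amine or a carboxylic acid would do so, since every group shown here is either a plain carbon ring or a fluorophenyl.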